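N-Methylation of an Indole Amide: Expected Effect on Cytotoxicity

The source may report more compounds than this note shows. Statements on the series, on what has been measured and on what is new or still open speak of the compounds shown alone.

Measured so far:
- compound 1, `COc1ccc(Cn2cc(/C=N\NC(=O)c3c[nH]c4ccc(Br)cc34)c3cc(OC)ccc32)cc1`: 28000 nM
- compound 2, `COc1ccc2c(c1)c(/C=N\NC(=O)c1c[nH]c3ccc(Br)cc13)cn2Cc1ccc(Cl)cc1`: 15900 nM
- compound 3, `O=C(N/N=C\c1cn(Cc2ccc(Cl)cc2)c2cc(F)ccc12)c1c[nH]c2ccccc12`: 19500 nM

All three compounds were tested in a functional assay on PC-3 cells (Homo sapiens) for cytotoxicity; on this read-out lower numbers stand for stronger inhibition and higher numbers for weaker inhibition. Compound 3 holds the second highest of the three numbers; its nearest neighbour is compound 2, its furthest compound 1, and both gaps lie within the scatter of repeated measurement, so no order among the three can be claimed.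

The step from compound 3 to compound 4 concerns the amide-bearing end of the molecule. Compound 4, `Cn1cc(C(=O)N/N=C\c2cn(Cc3ccc(Cl)cc3)c3cc(F)ccc23)c2ccccc21`, differs from compound 3 by methyl in place of hydrogen on an aromatic nitrogen; the five-membered ring concerned belongs to a fused system of two rings, and one bond further out the change reads 1H-indol-3-yl to 1-methyl-1H-indol-3-yl.

Within the data shown here, the only measured step, a 1.8-fold lower number from compound 1 to compound 2 (0.25 log units; within the scatter), swaps one group for another on an aromatic carbon and therefore says nothing about a methyl on an aromatic nitrogen. Among the measured compounds shown here, no measured pair carries this change, so there is no basis for expecting a shift beyond the scatter in this assay in either direction.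

Compound 4 is therefore expected to give about 20000 nM, with a plausible range from 7000 nM to 60000 nM, an estimated step of a 1.0-fold higher number from compound 3 to compound 4 (0.01 log units; within the scatter).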

Compound 4, half-maximal inhibitory concentration: 22100 nM
The estimate for compound 4 lay 1.1-fold (0.04 log units) below the measured number; low and high end bracket the measured number.
By their numbers in this assay, from the lowest: compounds 2, 3, 4 and 1 (each within the scatter of the next).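

In this assay, putting methyl in place of hydrogen on the aromatic nitrogen, which turns 1H-indol-3-yl into 1-methyl-1H-indol-3-yl, gives a 1.1-fold higher number from compound 3 to compound 4 (0.05 log units; within the scatter). Among these compounds, this is the first measured pair to carry a change at this nitrogen, since the earlier step concerned a group on an aromatic carbon, and it shows that in this compound the hydrogen can be exchanged for methyl with no change that can be told apart from the scatter of repeated measurements. No measurement shown here accounts for this outcome.

The compounds shown leave open whether anything larger or different on this nitrogen, such as a longer chain like n-propyl or a chain ending in an amine or a carboxylic acid, would move the number beyond the scatter. They also leave open whether methyl at this nitrogen would have the same small effect in compound 2, which differs from compound 3 elsewhere in the molecule, so this single pair cannot yet be read as a general rule.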